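Swapping a Pyridine Amide for a Methoxyacetamide

A few compounds are considered here, and "the series" means these few. Any claim that something is new, unique, unknown or untested is made for them only; others in the source may bear on it.

Compound 1 `CC(C)CC(=O)N1CCc2cc(CNC(=O)c3cccnc3)ccc21` and compound 2 `CCC(=O)N1CCc2cc(CNC(=O)c3cccs3)ccc21` share the same core and differ only in the acyl group on its nitrogen and in the group on the far amide. In an assay on HEK293 cells for inhibition of Indoleamine 2,3-dioxygenase 1 (Homo sapiens), tested at 10 uM (a higher number here means more inhibition at the concentration tested (going by the name of the read-out), a lower number less inhibition), compound 1 gives 86%, and compound 2 gives 89%. The number for compound 1 is the lower of the two, but the gap to compound 2 lies within the usual scatter, so the two compounds read as equivalent here.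

Compound 3 `COCC(=O)NCc1ccc2c(c1)CCN2C(=O)CC(C)C` has not yet been measured. It differs from compound 1 in one place: methoxymethyl in place of pyridin-3-yl on a carbonyl carbon. What leaves is one six-membered aromatic ring with one hetero atom; what enters is a short chain with no ring, keeping one hydrogen-bond acceptor. Among the measured compounds shown here, no measured pair shows a change of this kind, so its size cannot be read from the data. The expected step in this assay is a loss of inhibition, a number 31 percentage points lower from compound 1 to compound 3 (beyond the scatter), well beyond the scatter. On that basis compound 3 is estimated at 55%, with a range from 20% to 85%.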

Compound 3, a percentage reported as inhibition, at one concentration (the size of the read-out at that concentration, not a potency): 20%
For compound 3 the middle estimate is 35 percentage points above the measured one; the measured number falls inside the stated range.
By their numbers in this assay, from the lowest: compound 3; then compounds 1 and 2 (each within the scatter of the next).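

Going to methoxymethyl in place of pyridin-3-yl on a carbonyl carbon gives, in this assay, a number 66 percentage points lower from compound 1 to compound 3 (beyond the scatter), and this is the first single change in the series whose effect can be read on its own, since the earlier pair differed in two places at once. The two groups have the same count of hydrogen-bond acceptors, so a retained acceptor on this carbonyl carbon is not enough on its own to preserve inhibition; what the swap removes is a six-membered aromatic ring with one hetero atom, and the chain that enters has fewer heavy atoms. No measurement here explains why the number drops so far.

This single pair cannot separate the loss of the ring from the loss of its nitrogen or from the smaller size of the group, and a phenyl ring or a cyclohexyl ring at this position would help tell these apart. As far as these compounds go, a longer chain such as methoxyethyl would show whether size alone recovers any of the inhibition, and it also remains open whether the step is the same with another acyl group on the core nitrogen.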